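Series notes: amide aryl group exchange on sulfamoylurea core

The compounds below may be only part of what the source reports. "The series", "measured", "known", "first", "only" and "open" are said of these compounds alone.

Measured so far:
compound 1 `COc1ccc(Cl)cc1C(=O)NCCC1CCN(S(=O)(=O)NC(=O)NC[C@@H]2C[C@@H]3C=C[C@@H]2C3)CC1`: 37%
compound 2 `COc1ccncc1C(=O)NCCC1CCN(S(=O)(=O)NC(=O)NC[C@@H]2C[C@@H]3C=C[C@@H]2C3)CC1`: 14%

In a functional assay on the whole organism (blood) with Rattus norvegicus as the target, with stated times of 24 h and 1 h, at a dose of 5 mg/kg by the intraperitoneal route (a higher number here means a stronger effect of the compound at the dose given, a lower number a weaker effect), compound 2 gives 14%, the lowest of the two numbers; its nearest neighbour is compound 1, and the step of a number 23 percentage points lower from compound 1 to compound 2 (beyond the scatter) lies beyond the scatter. Compound 3 `Cn1cc(C(=O)NCCC2CCN(S(=O)(=O)NC(=O)NC[C@@H]3C[C@@H]4C=C[C@@H]3C4)CC2)c(=O)n(C)c1=O` differs from compound 2 as follows: a group of 10 heavy atoms (6 carbon, 2 nitrogen, 2 oxygen; one six-membered aromatic ring with 2 hetero atoms) in place of a group of 8 heavy atoms (6 carbon, 1 nitrogen, 1 oxygen; one six-membered aromatic ring with 1 hetero atom), on a carbonyl carbon. Going by the values given here, no measured step replaces the 4-methoxypyridin-3-yl group by anything; the only step known, a number 23 percentage points lower from compound 1 to compound 2 (beyond the scatter), concerns a different exchange and offers no direction for this one. The expected step is therefore a number 1 percentage points higher from compound 2 to compound 3 (within the scatter), not beyond the scatter. The estimate for compound 3 is 15%, with a range from 2% to 35%.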

Compound 3, a percentage reported as activity, at one dose (the size of the read-out at that dose, not a potency): 23%
Beside the measured number, compound 3's estimate is 8 percentage points below it; low and high end bracket the measured number.
By their numbers in this assay, from the lowest: compounds 2 and 3 (each within the scatter of the next); then compound 1.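

The step of a number 9 percentage points higher from compound 2 to compound 3 (within the scatter) in this assay does not separate the two replacement groups on this carbonyl carbon. The step of a number 14 percentage points lower from compound 1 to compound 3 (beyond the scatter) shows that a second replacement of the 5-chloro-2-methoxyphenyl group also gives a lower number, so among these three compounds the group of compound 1 gives the highest reading. No measurement bearing on the reason for either step is available.

On these data alone, whether the chlorine or the methoxy group of compound 1 matters more remains open. A phenyl group carrying only chlorine, or only methoxy, would separate the two.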